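The compounds below may be only part of what the source reports. "The series", "measured", "known", "first", "only" and "open" are said of these compounds alone.

Series notes, alkyne-linked pyridyl ethers of the shared core.

Within the data shown here, compound 3 `CN1CCC[C@H]1COc1cncc(C#CCCCCO)c1` gives 0.85 nM in an assay on a protein complex for binding affinity to Neuronal acetylcholine receptor; alpha4/beta2 (Rattus norvegicus) (a lower number here means a stronger inhibitor, a higher number a weaker inhibitor), the lowest of the three numbers so far, though its nearest neighbours sit within the scatter: compound 2 `CN1CCC[C@H]1COc1cncc(C#CCO)c1` gives 0.93 nM and compound 1 `CN1CCC[C@H]1COc1cncc(C#CCCCCF)c1` gives 0.95 nM. The measured steps are all flat: a 1.0-fold lower number from compound 1 to compound 2 (0.01 log units; within the scatter), a 1.1-fold lower number from compound 1 to compound 3 (0.05 log units; within the scatter) and a 1.1-fold lower number from compound 2 to compound 3 (0.04 log units; within the scatter). Exchanging fluoro for hydroxy, or lengthening the chain from hydroxy to 3-hydroxypropyl, leaves the number unchanged.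

Compound 4 `CN1CCC[C@H]1COc1cncc(C#Cc2ccccc2)c1` takes a different route: phenyl in place of 4-hydroxybutyl on a triple-bonded carbon. The measured steps bear on it only indirectly; they show that the chain end tolerates hydroxy, fluoro and varying length without effect, but none of them brings in a ring or removes the chain entirely. By that tolerance compound 4 is expected to stay near the others, with the step of a 1.8-fold higher number from compound 3 to compound 4 (0.25 log units; within the scatter) estimated as small and the range widened for the untested aromatic group. The estimate for compound 4 is 1.5 nM, between 0.4 nM and 6 nM.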

Compound 4, inhibition constant: 0.51 nM
Compound 4: middle estimate off by 2.9-fold (0.47 log units), on the high side; low and high end bracket the measured number.
By their numbers in this assay, from the lowest: compounds 4, 3, 2 and 1 (each within the scatter of the next).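

On a triple-bonded carbon in this assay, an aromatic ring serves as well as an open chain: phenyl in place of 4-hydroxybutyl gives a 1.7-fold lower number from compound 3 to compound 4 (0.22 log units; within the scatter) and phenyl in place of hydroxymethyl gives a 1.8-fold lower number from compound 2 to compound 4 (0.26 log units; within the scatter) while phenyl in place of 4-fluorobutyl gives a 1.9-fold lower number from compound 1 to compound 4 (0.27 log units; within the scatter) and so all three steps stay within the scatter. The tolerance seen among chains therefore extends to a six-membered aromatic ring of carbon only, with 0 hydrogen-bond donors and 0 hydrogen-bond acceptors. No supporting data bear on why this position accepts such different groups.

No group shown here moves the number beyond the scatter, so the limits of this tolerance remain undefined. From the compounds shown here alone, it remains open whether a carboxylic acid or an amine at the chain end, a longer chain, or a phenyl carrying a chloro or methoxy group would hold the number.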